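The source may hold more compounds than are shown below. What is called first, only, known or untested is meant among the compounds shown, and "the series" means these compounds.

Measured in a functional assay on MDA-MB-231 cells (Homo sapiens) for antiproliferative activity, read by MTT assay, with a stated time of 48 h; on this read-out higher numbers stand for weaker inhibition and lower numbers for stronger inhibition:
Compound 1 `CN1CCN(c2ccc(-c3cc4c(N5CCN(C(=O)Nc6cccc(F)c6)CC5)ncnc4s3)cc2)CC1`: 13200 nM
Compound 2 `COc1ccccc1NC(=O)N1CCN(c2ncnc3sc(-c4ccc(N5CCN(C)CC5)cc4)cc23)CC1`: 23200 nM

Only these two compounds have been measured, so compound 2 has a single neighbour to be compared with. Its value of 23200 nM lies within the scatter of the value for compound 1, and the pair cannot be ranked in this assay.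

Compound 3 `CC(C)c1cccc(C(C)C)c1NC(=O)N1CCN(c2ncnc3sc(-c4ccc(N5CCN(C)CC5)cc4)cc23)CC1` keeps the core of compound 2 and changes one group: 2,6-diisopropylphenyl in place of 2-methoxyphenyl on an amide-type nitrogen. Here 2,6-diisopropylphenyl takes the place of 2-methoxyphenyl on an amide-type nitrogen.

Among the compounds with values here, one measured step bears on this change, since it concerns the same place: a 1.8-fold higher number from compound 1 to compound 2 (0.24 log units; within the scatter), where 2-methoxyphenyl replaces 3-fluorophenyl. That step stays within the scatter, which gives no ground to expect a real shift in either direction. Within the data shown here, no measured compound carries 2,6-diisopropylphenyl, however, so the expectation rests on thin evidence and the range is kept wide.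

The expected change is a 1.2-fold lower number from compound 2 to compound 3 (0.06 log units; within the scatter), which would be no step beyond the scatter. For compound 3 the estimated value is 20000 nM, with an expected range from 8000 nM to 50000 nM.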

Compound 3, half-maximal inhibitory concentration: 8430 nM
For compound 3 the middle estimate is 2.4-fold (0.38 log units) above the measured one; low and high end bracket the measured number.
By their numbers in this assay, from the lowest: compounds 3, 1 and 2 (each within the scatter of the next, the first and the last beyond it).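

In this assay, the group on the amide-type nitrogen now gives a step beyond the scatter: a 2.8-fold lower number from compound 2 to compound 3 (0.44 log units; beyond the scatter), modest in size, with 2,6-diisopropylphenyl in place of 2-methoxyphenyl, whereas the earlier step, a 1.8-fold higher number from compound 1 to compound 2 (0.24 log units; within the scatter), left its pair unranked. The same group gives no such separation when it takes the place of 3-fluorophenyl, a 1.6-fold lower number from compound 1 to compound 3 (0.19 log units; within the scatter), so the position responds only in the comparison with 2-methoxyphenyl, and the result does not establish a general advantage for 2,6-diisopropylphenyl. Nothing available accounts for the step between the two groups, which differ in heavy atoms and in the oxygen that leaves.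

On these data alone, it remains open whether a phenyl ring carrying smaller groups, such as methyl or ethyl, would read like 2,6-diisopropylphenyl or like 2-methoxyphenyl, and whether a saturated ring such as cyclohexyl on the same nitrogen would serve in place of the aromatic ring. Also open, as far as these compounds go, is how an amine or a carboxylic acid on that phenyl ring would read in this assay.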